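Chloro to bromo on the aryl ring: working notes

The compounds below may be only part of what the source reports. "The series", "measured", "known", "first", "only" and "open" are said of these compounds alone.

Measured so far in a functional assay on the whole organism for inhibition, with Rattus norvegicus as the target, read by paw edema, with a stated time of 2 h, at a dose of 50 mg/kg; a lower number here means less inhibition, a higher number more inhibition at the dose given (going by the name of the read-out):
- compound 1 `Cc1ccc(-n2nc3cc(C)oc(=O)c3c2C)cc1`: 58.4%
- compound 2 `Cc1cc2nn(-c3ccc(Cl)cc3)c(C)c2c(=O)o1`: 59.6%

In this assay, for the measured compounds named here, compound 2 gives 59.6%; the only other number, compound 1 at 58.4%, lies within the scatter of it. Compound 3 `Cc1cc2nn(-c3ccc(Br)cc3)c(C)c2c(=O)o1` differs from compound 2 by bromo in place of chloro on an aromatic carbon. Going by the values given here, the single measured step, a number 1.2 percentage points higher from compound 1 to compound 2 (within the scatter), was also a change on an aromatic carbon and stayed within the scatter; no chloro-to-bromo step has been measured. A step of no more than the scatter is therefore expected in this assay. Compound 3 is estimated at 60%, range 48% to 72%. The expected shift is a number 0.4 percentage points higher from compound 2 to compound 3 (within the scatter).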

Compound 3, a percentage reported as inhibition, in the whole organism at one dose (the size of the read-out at that dose, not a potency): 50.6%
Compound 3: the middle estimate sits 9.4 percentage points above what was measured; low and high end bracket the measured number.
By their numbers in this assay, from the lowest: compounds 3, 1 and 2 (each within the scatter of the next).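

In this assay bromo joins methyl and chloro on the aromatic carbon para to a large group, and both new steps, a number 9 percentage points lower from compound 2 to compound 3 (within the scatter) and a number 7.8 percentage points lower from compound 1 to compound 3 (within the scatter), stay within the usual scatter. Methyl, chloro and bromo at this place are therefore not separated by this read-out, which now holds for a chloro-to-bromo change as well. No available evidence bears on this result.

On these data alone, whether an amine, a carboxylic acid or a methoxy group at this place would give a number beyond the scatter remains open. The read-out at one dose also leaves the potency of these compounds open.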